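Changing the amino side group of compound 2

A few compounds are considered here, and "the series" means these few. Any claim that something is new, unique, unknown or untested is made for them only; others in the source may bear on it.

Compound 1 `CC[C@@H](Nc1c(C#N)c(-c2ccc(-c3ccccc3F)cc2)nc2cnccc12)C(N)=O` gives 2.7
Compound 2 `CN(CC(N)=O)c1c(C#N)c(-c2ccc(Br)cc2)nc2cnccc12` gives 2.1

In a physicochemical assay for lipophilicity, read by HPLC, at pH 7.5 (on this read-out higher numbers stand for higher lipophilicity and lower numbers for lower lipophilicity), compound 2 (2.1) is the lower of the two numbers, and compound 1 (2.7) lies beyond the scatter above it. Compound 3 (`CC[C@@H](Nc1c(C#N)c(-c2ccc(Br)cc2)nc2cnccc12)C(N)=O`) has (1-carbamoylpropyl)amino in place of the (carbamoylmethyl)(methyl)amino of compound 2 on an aromatic carbon ((1-carbamoylpropyl)amino in place of (carbamoylmethyl)(methyl)amino on an aromatic carbon). Going by the values given here, no measured pair shows this change alone. Compound 1 (2.7) carries the same (1-carbamoylpropyl)amino but lacks the 4-bromophenyl group, so it is only a loose guide. A small upward change is expected (a number 0.30 log units higher from compound 2 to compound 3 (within the scatter)) in this assay and may not clear the scatter. Compound 3 is estimated at 2.4 (expected range 2 to 2.8).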

Compound 3, distribution coefficient: 2.2
Beside the measured number, compound 3's estimate is 0.20 log units above it; measured number inside the range.
By their numbers in this assay, from the lowest: compounds 2 and 3 (each within the scatter of the next); then compound 1.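

In this assay, (1-carbamoylpropyl)amino in place of (carbamoylmethyl)(methyl)amino on this aromatic carbon gives a number 0.10 log units higher from compound 2 to compound 3 (within the scatter) and so does not separate the two side groups at this position. The larger step lies at the other place, where bromo in place of 2-fluorophenyl gives a number 0.50 log units lower from compound 1 to compound 3 (beyond the scatter) on the same side group. No measurement offered here gives a reason for either step. As far as these compounds go, it remains open whether a carboxylic acid in place of the carbamoyl group would shift the number in this assay beyond the scatter. The same holds for a longer chain than the propyl on the amino group.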